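Hydroxyethylamino substitution on the pyrimidine of a urea series

A few compounds are considered here, and "the series" means these few. Any claim that something is new, unique, unknown or untested is made for them only; others in the source may bear on it.

Measured compounds:
compound 1 `CNc1cc(Oc2ccc(NC(=O)Nc3cccc(C(F)(F)F)c3)c(F)c2F)ncn1`, 20 nM
compound 2 `O=C(Nc1ccc(Oc2ccncn2)cc1)Nc1cccc(C(F)(F)F)c1`, 160 nM

Both compounds were tested in an assay on isolated protein for inhibition of serine/threonine-protein kinase TNNI3K (Homo sapiens); a lower number here means a stronger inhibitor, a higher number a weaker inhibitor. Compound 2 has the higher of the two numbers, so it is the weaker inhibitor; compound 1 gives 20 nM, a difference that lies beyond the usual scatter. Compound 1 differs from compound 2 in more than one place, so no single change can be read from that pair.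

Compound 3 `O=C(Nc1ccc(Oc2cc(NCCO)ncn2)cc1)Nc1cccc(C(F)(F)F)c1` has not yet been measured in this assay. It differs from compound 2 in one place: (2-hydroxyethyl)amino in place of hydrogen on an aromatic carbon.

Among the measured compounds shown here, no measured pair shows this exact change. Given that compound 2 is the weaker compound and that compound 1, which also carries a substituted amino group on its core, gives 20 nM, the expected step is a moderate move toward stronger inhibition, a 3.2-fold lower number from compound 2 to compound 3 (0.51 log units; beyond the scatter), though it could also fall within the scatter. Compound 3 is expected to give about 50 nM, in the range 15 nM to 160 nM.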

Compound 3, half-maximal inhibitory concentration: 32 nM
For compound 3 the middle estimate is 1.6-fold (0.19 log units) above the measured one; measured number inside the range.
By their numbers in this assay, from the lowest: compounds 1 and 3 (each within the scatter of the next); then compound 2.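

In this assay, among the compounds shown here, putting (2-hydroxyethyl)amino in place of hydrogen gives a 5.0-fold lower number from compound 2 to compound 3 (0.70 log units; beyond the scatter) and is the first change here that can be read on its own. It shows that this aromatic carbon, next to the ring nitrogen, accepts a substituent with a gain in inhibition rather than a loss, and the step lies beyond the usual scatter. No measurement here accounts for that gain, so it cannot be assigned to the nitrogen, the hydroxyl or the chain as a whole.

Ethylamino, which lacks the hydroxyl, would test what that oxygen adds at this position. On these data alone, whether a plain amino group or a longer chain such as (3-hydroxypropyl)amino would do as well also remains open.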